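From Dimethylisoxazole to Bromopyridine on a Sulfonyl Sulfur

The source may hold more compounds than are shown below. What is called first, only, known or untested is meant among the compounds shown, and "the series" means these compounds.

Compound 1 `Cc1cc(C)c(S(=O)(=O)N2CCN(C3CN4CCC3CC4)CC2)c(C)c1`: 84 nM
Compound 2 `Cc1noc(C)c1S(=O)(=O)N1CCC(N2CCC(C)CC2)CC1`: > 5000 nM

Of the compounds shown here, two have been measured in a functional assay on DLD-1 cells (Homo sapiens) for antiproliferative activity, read by CellTiter-Glo, with a stated time of 72 h; a lower number here means a stronger inhibitor, a higher number a weaker inhibitor. Compound 1 gives 84 nM. Compound 2 reaches only a limit of the assay, > 5000 nM, so its place is the limit of > 5000 nM in this assay, at which 1 of the 2 values shown sits, and no number is known for it. Compound 3 `CC1CCN(C2CCN(S(=O)(=O)c3cncc(Br)c3)CC2)CC1` differs from compound 2 by 5-bromopyridin-3-yl in place of 3,5-dimethyl-1,2-oxazol-4-yl on a sulfonyl sulfur. Within the data shown here, no step between measured compounds that differ in one place is known, so the expected size of this change in this assay rests on compound 2 alone. Compound 3 is expected to stay near that limit, with a step of an at least 1.4-fold lower number from compound 2 to compound 3 (0.15 log units; that floor lies within the scatter) that need not exceed the scatter. Compound 3 is estimated at 3500 nM, from 600 nM to 15000 nM.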

Compound 3, half-maximal inhibitory concentration: > 5000 nM
Compound 3: a limit, no number; the forecaster's own chance of this, stated with the estimate: 45%; middle value at least 1.4-fold (0.15 log units) away from the limit.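

In this assay, among these compounds, compound 3 gives only a limit of > 5000 nM so no step from compound 2 can be read: the limit of > 5000 nM in this assay, at which 2 of the 3 values shown sit. As far as these compounds go, how far either compound lies past that limit remains open.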